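The compounds below may be only part of what the source reports. "The series", "measured", "known", "first", "only" and "open" are said of these compounds alone.

Compound 1 `COc1ccc(/C=C/C(=O)c2ccc(OC)c3c2OC(C)(C)C=C3)cc1OCC=C(C)C` — a functional assay on HepG2 cells (Homo sapiens) for cytotoxicity, read by MTT assay; on this read-out higher numbers stand for weaker inhibition and lower numbers for stronger inhibition: a limit only, > 10000 nM
Compound 2 `COc1ccc(/C=C/C(=O)c2ccc(OC)c3c2OC(C)(C)C=C3)cc1OC(=O)CCl` — 120 nM
Compound 3 `COc1cccc(C(=O)Oc2cc(/C=C/C(=O)c3ccc(OC)c4c3OC(C)(C)C=C4)ccc2OC)c1` — 870 nM

Compound 1 gives only a limit in this assay (the limit of > 10000 nM in this assay, at which 1 of the 3 values shown sits), and among the three it stands at the weak end. Both measured steps away from it bear on the new compound: an at least 83-fold lower number from compound 1 to compound 2 (1.92 log units; beyond the scatter) and an at least 11-fold lower number from compound 1 to compound 3 (1.06 log units; beyond the scatter), each a large step downward when 3-methylbut-2-en-1-yl gives way to a carbonyl-bearing group on the same oxygen. Compound 4 `COc1ccc(/C=C/C(=O)c2ccc(OC)c3c2OC(C)(C)C=C3)cc1OS(=O)(=O)Cc1ccccc1` differs from compound 1 in the same place: benzylsulfonyl in place of 3-methylbut-2-en-1-yl on an oxygen on an aromatic ring. By analogy with compound 2 and compound 3, a large step downward, beyond the scatter, is expected. The expected step is an at least 20-fold lower number from compound 1 to compound 4 (1.30 log units; beyond the scatter). Compound 4 is therefore estimated at 500 nM in this assay, with a range of 100 nM to 3000 nM.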

Compound 4, half-maximal inhibitory concentration: > 10000 nM
Compound 4 gave a limit, no number; the forecaster's own chance of this, stated with the estimate: 10%; at least 20-fold (1.30 log units) between middle value and limit.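

In this assay a carbonyl-bearing group on this oxygen is not matched by every replacement for 3-methylbut-2-en-1-yl: benzylsulfonyl in that place gives an at least 83-fold higher number from compound 2 to compound 4 (1.92 log units; beyond the scatter) and also an at least 11-fold higher number from compound 3 to compound 4 (1.06 log units; beyond the scatter) in the same comparison. Among the compounds shown, only compound 2 and compound 3 reach readable values, and they carry the carbonyl-bearing groups. Compound 4 gives only a limit, and its step from compound 1 cannot be read: the limit of > 10000 nM in this assay, at which 2 of the 4 values shown sit.

Open, going by these compounds, is whether methylsulfonyl on this oxygen would give a readable value. Also open, on these data alone, is what acetyl or a free hydroxyl would give in this place.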